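Hydrazone aryl swap in a cytotoxicity series

The source may hold more compounds than are shown below. What is called first, only, known or untested is meant among the compounds shown, and "the series" means these compounds.

Of the compounds shown here, two sharing one core have been tested in a functional assay on MCF7 cells (Homo sapiens) for cytotoxicity, read by MTT assay, with a stated time of 48 h; a lower number here means a stronger inhibitor, a higher number a weaker inhibitor. Compound 1 `COc1cccc(/C=N/NC(=O)CSc2nnc(-c3ccncc3)o2)c1` gives 13800 nM in this assay. For the measured compounds named here, compound 2 `O=C(CSc1nnc(-c2ccncc2)o1)N/N=C/c1ccccc1[N+](=O)[O-]` gives 35600 nM in this assay, the highest of the two numbers; the only step recorded, a 2.6-fold higher number from compound 1 to compound 2 (0.41 log units; beyond the scatter), moves to it from compound 1 and is modest.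

Compound 3 `O=C(CSc1nnc(-c2ccncc2)o1)N/N=C/c1cc(Cl)cc(Cl)c1O` has not yet been measured. It differs from compound 2 in one place: 3,5-dichloro-2-hydroxyphenyl in place of 2-nitrophenyl on a carbon with a double bond to nitrogen. Going by the values given here, only the step from compound 1 to compound 2 bears on this change, and it shows that replacing the aryl group on the carbon with a double bond to nitrogen shifts the number by a modest amount. Among the compounds with values here, no measured pair involves a hydroxyl or chlorine on that aryl group, so the direction for compound 3 rests on weak ground. Compound 3 is therefore expected to land near compound 2, with a step of a 2.0-fold lower number from compound 2 to compound 3 (0.30 log units; within the scatter) that may fall within or just beyond the scatter. The estimate for compound 3 in this assay is 18000 nM, between 6000 nM and 50000 nM.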

Compound 3, half-maximal inhibitory concentration: 5920 nM
The estimate for compound 3 lay 3.0-fold (0.48 log units) above the measured number, and the stated range ends above it.
By their numbers in this assay, from the lowest: compound 3; then compound 1; then compound 2.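

In this assay, the aryl group on a carbon with a double bond to nitrogen proves able to lower the number as well as raise it: 3,5-dichloro-2-hydroxyphenyl in place of 2-nitrophenyl gives a 6.0-fold lower number from compound 2 to compound 3 (0.78 log units; beyond the scatter). The same group also improves on 3-methoxyphenyl, with a 2.3-fold lower number from compound 1 to compound 3 (0.37 log units; beyond the scatter), which makes compound 3 the strongest inhibitor of the three, as its steps to both other compounds lie beyond the scatter. Nothing measured here accounts for these shifts, and no cause can be assigned to the change.

The hydroxyl and the two chlorines enter together in compound 3, and no compound shown carries only one of these features on the aryl group, so their separate contributions remain unresolved. For the compounds shown here, it also remains open how the number would respond to an amine or a carboxylic acid on that aryl group, and whether any of these steps would hold on a core with a longer chain in place of the one shared by these compounds.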